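From Fluorobenzyl to Methoxyindole: Tolerance on Vero Cells

The compounds below may be only part of what the source reports. "The series", "measured", "known", "first", "only" and "open" are said of these compounds alone.

Three compounds that share one core have been examined in an ADME assay on Vero C1008 cells (Chlorocebus sabaeus) for cytotoxicity, read by luminescence and CellTiter-Glo, with a stated time of 24 h; a lower number here means that less compound is tolerated, a higher number that more compound is tolerated. Compound 1 `O=C(N[C@@H](CC1CC1)C(=O)N[C@@H](C[C@@H]1CCNC1=O)C(O)S(=O)(=O)O)OCc1ccccc1` carries a benzyloxy group on the carbonyl carbon. In this assay compound 1 gives > 200000 nM, which is a limit of the assay and not a number. Compound 2 `COc1cccc2[nH]c(C(=O)N[C@@H](CC(C)C)C(=O)N[C@@H](C[C@@H]3CCNC3=O)C(O)S(=O)(=O)O)cc12` carries the 4-methoxy-1H-indol-2-yl group on that carbonyl carbon. In this assay compound 2 gives > 200000 nM, again a limit rather than a number. Compound 3 `O=C(N[C@@H](CC1CC1)C(=O)N[C@@H](C[C@@H]1CCNC1=O)C(O)S(=O)(=O)O)OCc1cccc(F)c1` differs from compound 1 by fluoro in place of hydrogen on an aromatic carbon. In this assay compound 3 gives > 200000 nM, also a limit. The step that the two limits leave unreadable from compound 1 to compound 3 cannot be read because of the limit of > 200000 nM in this assay, at which 3 of the 3 values shown sit. Compound 3 thus stands at the limit, with only a range known for it.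

Compound 4 `COc1cccc2[nH]c(C(=O)N[C@@H](CC3CC3)C(=O)N[C@@H](C[C@@H]3CCNC3=O)C(O)S(=O)(=O)O)cc12` is the next compound. It differs from compound 3 by 4-methoxy-1H-indol-2-yl in place of (3-fluorobenzyl)oxy on a carbonyl carbon. For the measured compounds named here, no measured step bears directly on this change; what can be said is that compound 2, which already holds the 4-methoxy-1H-indol-2-yl group, sits at the same limit as compound 3. The step of a number no higher from compound 3 to compound 4 (the limit leaves the size open) is therefore expected to be none beyond the scatter. Compound 4 is expected to give 200000 nM, estimated to lie between 100000 nM and 400000 nM.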

Compound 4, half-maximal cytotoxic concentration: > 200000 nM
Compound 4 ended at the assay's limit; the forecaster's own chance of this, stated with the estimate: 85%; the middle value lies on the limit itself.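

No step from compound 1, compound 2 or compound 3 to compound 4 can be read in this assay, because each value is only a limit: the limit of > 200000 nM in this assay, at which 4 of the 4 values shown sit.

The compounds shown leave open at what concentration any of the four becomes cytotoxic, and whether the exchanged groups make any difference to it.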